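The source may hold more compounds than are shown below. What is called first, only, known or untested is meant among the compounds shown, and "the series" means these compounds.

In a functional assay on HEK293 cells for agonist activity at G-protein coupled receptor 52 (Homo sapiens), read by cAMP accumulation, with a stated time of 15 min (on this read-out higher numbers stand for larger maximal responses and lower numbers for smaller maximal responses), compound 1 `O=C(NCCO)c1cccc2c1CCN2c1ccnc(Cc2cc(F)cc(C(F)(F)F)c2)n1` gives 144% and compound 2 `O=C(NCCO)c1cccc2c1CCN2c1cc(Cc2ccccc2C(F)(F)F)ncn1` gives 115%. Compound 2 thus stands lowest of the two numbers, with compound 1 higher by a margin beyond the scatter. Compound 3 `Cc1cccc(Cc2cc(N3CCc4c(C(=O)NCCO)cccc43)ncn2)c1` differs from compound 2 by 3-methylphenyl in place of 2-(trifluoromethyl)phenyl on a saturated chain carbon bound to an aromatic carbon. For the measured compounds named here, no step between measured compounds in this assay is available, so the two values alone frame the expectation. The expected step, a number 10 percentage points higher from compound 2 to compound 3 (within the scatter), is a modest rise, at or just beyond the scatter. The estimate for compound 3 in this assay is 125%, with a range of 95% to 150%.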

Compound 3, largest response reached (Emax), in percent of the reference or control that the assay uses: 144%
The estimate for compound 3 lay 19 percentage points below the measured number; the range from low to high includes it.
By their numbers in this assay, from the lowest: compound 2; then compounds 1 and 3 (each within the scatter of the next).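

In this assay, for the compounds shown here, there is a number 29 percentage points higher from compound 2 to compound 3 (beyond the scatter) with 3-methylphenyl in place of 2-(trifluoromethyl)phenyl on a saturated chain carbon bound to an aromatic carbon, the first single-place change. The maximal response thus depends on the aryl group at this position, and that group need not carry fluorine. Nothing at hand accounts for the step.

Still open, going by these compounds, is whether the step follows the group itself or its place on the ring, which 2-methylphenyl and 3-(trifluoromethyl)phenyl would separate. On these data alone, how a carboxylic acid or an amine on that ring would read also remains open.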